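The source may report more compounds than this note shows. Statements on the series, on what has been measured and on what is new or still open speak of the compounds shown alone.

In an ADME assay on MT4 cells (Homo sapiens) for cytotoxicity, read by MTT assay, with a stated time of 4 days (on this read-out higher numbers stand for lower toxicity in this test and lower numbers for higher toxicity in this test), the measured compounds stand as follows

compound 1 `C/C(=N\NC(=O)COc1cccc2ccccc12)c1ccc(C#N)cc1Br` gives 12.1 ug/mL
compound 2 `C/C(=N\NC(=O)COc1cccc2ccccc12)c1ccc(Cl)cc1` gives 4.07 ug/mL
compound 3 `O=C(COc1cccc2ccccc12)N/N=C/c1cccc(Br)c1` gives 87.4 ug/mL

Of these three, compound 2 has the lowest number, 4.07 ug/mL, and so shows the highest toxicity in this assay. The next compound to be read is compound 4 `C/C(=N\NC(=O)COc1cccc2ccccc12)c1ccc(O)cc1`, which differs from compound 2 as follows: hydroxy in place of chloro on an aromatic carbon. In words, this is hydroxy in place of chloro on an aromatic carbon.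

Going by the values given here, only one measured step touches this part of the structure: a 3.0-fold lower number from compound 1 to compound 2 (0.47 log units; beyond the scatter). Among the compounds with values here, that step is modest and replaces a different group, so it gives a rough size but no direct precedent for hydroxy. Within the data shown here, compound 3 differs from the other two in more than one place and yields no clean step, though its value of 87.4 ug/mL shows how far the numbers can spread in this small set. With compound 2 at the bottom of that spread, a modest move towards a higher number is expected, with little confidence in the direction.

The expected step is a 2.9-fold higher number from compound 2 to compound 4 (0.47 log units; beyond the scatter). The estimate for compound 4 is 12 ug/mL, with an expected range from 4 ug/mL to 50 ug/mL.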

Compound 4, half-maximal cytotoxic concentration: 68.8 ug/mL
Compound 4: the middle estimate sits 5.7-fold (0.76 log units) below what was measured, outside the stated range (above it).
By their numbers in this assay, from the lowest: compound 2; then compound 1; then compounds 4 and 3 (each within the scatter of the next).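

In this assay this position turns out to be highly sensitive: on an aromatic carbon para to a large group, hydroxy in place of chloro gives a 17-fold higher number from compound 2 to compound 4 (1.23 log units; beyond the scatter) and so marks a large change in toxicity in this test from the exchange of a single heavy atom. The earlier compounds shown here showed only a modest step on this ring, and compound 1 now lies between the two 4-substituted phenyl compounds: 4-chlorophenyl gives a 3.0-fold lower number from compound 1 to compound 2 (0.47 log units; beyond the scatter) while 4-hydroxyphenyl gives a 5.7-fold higher number from compound 1 to compound 4 (0.75 log units; beyond the scatter) in the opposite direction, so the outcome of replacing 2-bromo-4-cyanophenyl depends on the group at this place. No measurement at hand accounts for the size of this change or says which feature of the hydroxy group lies behind it.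

The compounds shown leave open whether the higher number is particular to hydroxy or is shared by a methoxy group, an amine or a carboxylic acid at the same place. They also leave open whether the exchange of chloro for hydroxy would give a step of similar size and direction on a core without the methyl group on the carbon with a double bond to nitrogen.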